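The source may report more compounds than this note shows. Statements on the series, on what has been measured and on what is new or still open speak of the compounds shown alone.

In an ADME assay on microsomes from liver (Homo sapiens) for metabolic stability, read by LC-MS, using NADPH, with a stated time of 10 min, tested at 0.1 uM (a lower number here means slower removal, a higher number faster removal of the compound), compound 1 `O=C(NCCCCc1ccccc1)c1cccc(C2SCC(=O)N2c2cccc(-c3c[nH]nn3)c2)c1` gives 261 mL.min-1.g-1, while compound 2 `C#Cc1cccc(N2C(=O)CSC2c2cccc(C(=O)NCCCCc3ccccc3)c2)c1` gives 751 mL.min-1.g-1, the higher of the two numbers. Compound 3 `O=C(NCCCCc1ccccc1)c1cccc(C2SCC(=O)N2c2ccccc2F)c1` has not yet been measured. It differs from compound 2 in one place: 2-fluorophenyl in place of 3-ethynylphenyl on an amide-type nitrogen in a ring. In words, 2-fluorophenyl stands in place of 3-ethynylphenyl on an amide-type nitrogen in a ring. Within the data shown here, only one measured step bears on this change, a 2.9-fold higher number from compound 1 to compound 2 (0.46 log units; beyond the scatter), a modest one that replaced 1H-1,2,3-triazol-4-yl with ethynyl on an aromatic carbon. Read in reverse, that step links the loss of ethynyl to a lower number, but it holds no compound with fluorine. A slightly lower number is therefore expected, with no step beyond the scatter. The estimated step is a 1.4-fold lower number from compound 2 to compound 3 (0.14 log units; within the scatter). Compound 3 is expected at 550 mL.min-1.g-1, within an estimated range of 250 mL.min-1.g-1 to 1100 mL.min-1.g-1.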

Compound 3, intrinsic clearance in microsomes: 1710 mL.min-1.g-1
For compound 3 the middle estimate is 3.1-fold (0.49 log units) below the measured one; the measured number lies above the stated range.
By their numbers in this assay, from the lowest: compound 1; then compound 2; then compound 3.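

In this assay, the group on the amide-type nitrogen in a ring can raise the number without any ethynyl or 1H-1,2,3-triazol-4-yl present (a 2.3-fold higher number from compound 2 to compound 3 (0.36 log units; beyond the scatter)), so removing ethynyl from this position does not by itself go with a lower number. The 2-fluorophenyl group also stands well apart from the triazole-bearing group at this position (a 6.6-fold higher number from compound 1 to compound 3 (0.82 log units; beyond the scatter)), which puts compound 3 highest of the three. No supporting data are given that would explain either step.

The compounds shown leave open whether the fluorine or the removal of the ethynyl accounts for the rise, a question that plain phenyl on this nitrogen would address. Going by these compounds, how 3-fluorophenyl or a phenyl bearing a carboxylic acid would stand here also remains open.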